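A few compounds are considered here, and "the series" means these few. Any claim that something is new, unique, unknown or untested is made for them only; others in the source may bear on it.

The measured compounds:

Compound 1, `CCCCCCCCCCCCS(=O)(=O)CC(O)(O)C(F)(F)F`, in an assay on isolated protein for inhibition of liver carboxylesterase 1 (Homo sapiens), with a stated time of 24 h (a higher number here means a weaker inhibitor, a lower number a stronger inhibitor), compound 1 gives 0.398 nM.
Compound 2, `CCCCCCCC[S+]([O-])CC(O)(O)C(F)(F)F`, in this assay compound 2 gives 0.603 nM.
Compound 3, `CCCCCCCCCCS(=O)(=O)CC(O)(O)C(F)(F)F`, in this assay compound 3 gives 0.302 nM.

Compounds 1 and 3 share a core and differ in one place: ethyl in place of hydrogen on a saturated chain carbon, ten or more bonds along the chain from a sulfonyl sulfur. That step was a 1.3-fold higher number from compound 3 to compound 1 (0.12 log units; within the scatter), so the chain extension left the inhibition constant essentially where it was. Compound 2 carries a different core; how its core differs from that of compound 3 is not broken down here. Its value sits within the scatter of both compound 1 and compound 3, so the three measured numbers do not separate from one another.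

Compound 4, `CCCCCCCCCC[S+]([O-])CC(O)(O)C(F)(F)F`, has not yet been measured. It differs from compound 2 by ethyl in place of hydrogen on a saturated chain carbon, eight bonds along the chain from a sulfur. Among the compounds with values here, this is the same kind of change as the one from compound 3 to compound 1, but not the same: the place along the chain from the sulfur differs between the two pairs, and in the measured pair that sulfur is a sulfonyl sulfur. Because the measured step of a 1.3-fold higher number from compound 3 to compound 1 (0.12 log units; within the scatter) lay within the scatter, the expected step for compound 4 is a 1.2-fold higher number from compound 2 to compound 4 (0.06 log units; within the scatter), a similarly small move. Compound 4 is therefore estimated at 0.7 nM, with a range from 0.3 nM to 1.6 nM.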

Compound 4, inhibition constant: 0.501 nM
Beside the measured number, compound 4's estimate is 1.4-fold (0.15 log units) above it; low and high end bracket the measured number.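

In this assay, the new step is a 1.2-fold lower number from compound 2 to compound 4 (0.08 log units; within the scatter), so ethyl in place of hydrogen on a saturated chain carbon again leaves the inhibition constant essentially where it stood. Set beside the earlier step, the change reads alike on the two cores, and the two steps cannot be told apart: the same change on two cores in this assay, a 1.3-fold higher number (0.12 log units; within the scatter) from compound 3 to compound 1 and a 1.2-fold lower number (0.08 log units; within the scatter) from compound 2 to compound 4, 1.6-fold (0.20 log units) apart, within the scatter of two such steps. This shows that, in these two pairs, the change carried from one core to the other without a separable effect on either; it does not show a step of fixed size or direction, as each step lies within the scatter, and two pairs, with the change at different places along the chain, cannot speak for other cores.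

The compounds shown leave open whether the same small step would hold for a longer chain, or for a chain bearing an amine or a carboxylic acid. They also leave open how the change would read on a core in which a group such as difluoromethyl stands in place of trifluoromethyl.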